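Triazolylamino Analogue Predicted from Three Azole Variants

The source may report more compounds than this note shows. Statements on the series, on what has been measured and on what is new or still open speak of the compounds shown alone.

Compound 1 has the structure `CC(C)C(c1ncc[nH]1)c1ccc(-c2ccc3cccc(F)c3c2)[nH]c1=O`. In an ADME assay on microsomes from liver (Mus musculus) for metabolic stability (on this read-out lower numbers stand for a shorter-lived compound and higher numbers for a longer-lived compound), compound 1 gives only a limit of the assay, < 0.0667 h, as the evidence notes: the limit of < 0.0667 h in this assay, at which 1 of the 3 values shown sits.
Compound 2 has the structure `CC(C)C(c1ccc(-c2ccc3cccc(F)c3c2)[nH]c1=O)N1CCNC1=O`; in this assay compound 2 gives 0.682 h.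
Compound 3 has the structure `CC(C)C(c1ncco1)c1ccc(-c2ccc3cccc(F)c3c2)[nH]c1=O`; in this assay compound 3 gives 0.08 h.

Among the two numbers reported, compound 3 stands lowest; its nearest neighbour is compound 2, seen in the step of an 8.5-fold lower number from compound 2 to compound 3 (0.93 log units; beyond the scatter). The comparison with compound 1 is an at least 1.1-fold higher number from compound 1 to compound 3 (0.07 log units; that floor lies within the scatter), a floor that lies within the scatter, so compound 1 and compound 3 cannot be ordered.

Compound 4, not yet measured, has the structure `CC(C)C(Nc1nnc[nH]1)c1ccc(-c2ccc3cccc(F)c3c2)[nH]c1=O`. It differs from compound 3 as follows: (4H-1,2,4-triazol-3-yl)amino in place of 1,3-oxazol-2-yl on a saturated chain carbon bound to an aromatic carbon and a saturated chain carbon.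

Of the measured steps, an at least 10-fold higher number from compound 1 to compound 2 (1.00 log units; beyond the scatter) and an 8.5-fold lower number from compound 2 to compound 3 (0.93 log units; beyond the scatter) show that replacing a small azole on that carbon with a group carrying hydrogen-bond donors raised the number well beyond the scatter, while an at least 1.1-fold higher number from compound 1 to compound 3 (0.07 log units; that floor lies within the scatter) shows two azoles barely apart. The entering group on compound 4 also brings hydrogen-bond donors, so a rise beyond the scatter is expected, though only compound 2 supports this pattern.

Compound 4 is therefore expected to give 0.35 h in this assay, between 0.09 h and 1.3 h, an expected step of a 4.4-fold higher number from compound 3 to compound 4 (0.64 log units; beyond the scatter).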

Compound 4, half-life: 2.42 h
Compound 4: the middle estimate sits 6.9-fold (0.84 log units) below what was measured, outside the stated range (above it).
By their numbers in this assay, from the lowest: compound 3; then compound 2; then compound 4. At a limit, below all of these: compound 1.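

For the compounds shown here, the (4H-1,2,4-triazol-3-yl)amino group shows that this place, on a saturated chain carbon bound to an aromatic carbon and a saturated chain carbon, can carry a longer half-life in this assay than the earlier compounds reached: the change gives a 30-fold higher number from compound 3 to compound 4 (1.48 log units; beyond the scatter), and it also gives a 3.5-fold higher number from compound 2 to compound 4 (0.55 log units; beyond the scatter), so the 2-oxoimidazolidin-1-yl group no longer marks the top of the series. The earlier compounds shown here left open whether a five-membered aromatic ring at this place always goes with a short half-life; compound 4 carries such a ring and has the highest number, although compound 1 and compound 3 still go with the low end. The remaining step, an at least 36-fold higher number from compound 1 to compound 4 (1.55 log units; beyond the scatter), is only a floor, set by a limit of the assay: the limit of < 0.0667 h in this assay, at which 1 of the 4 values shown sits.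

Going by these compounds, whether the rise belongs to the amino link or to the triazole ring stays open, since compound 4 differs from the other compounds in both at once, and a 4H-1,2,4-triazol-3-yl group bound directly to the carbon would be needed to part them. On these data alone, all four compounds share one core, so how far this holds on any other core also remains unknown.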